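Adding a methoxy to the shared core of compound 2

This account rests on a few compounds, and the source may have more. Where it says the series, first, only, none or still open, it means among the compounds named here.

Compound 1 `COc1c(N2CC[C@@H](CN)C2)c(F)cc2c(=O)c(C(=O)O)cn(Cc3ccc(-n4cccn4)cc3)c12`: > 200000 nM
Compound 2 `NC[C@@H]1CCN(c2cc3c(cc2F)c(=O)c(C(=O)O)cn3Cc2ccc(-c3ccc(F)cc3)cc2)C1`: 69600 nM

For the measured compounds named here, in an assay on isolated protein for inhibition of DNA topoisomerase 1 (Homo sapiens), with a stated time of 15 min (a lower number here means a stronger inhibitor, a higher number a weaker inhibitor), compound 2 gives 69600 nM, the only number in the set. For compound 1 the read-out is a limit of the assay and not a number, > 200000 nM, matching (the limit of > 200000 nM in this assay, at which 1 of the 2 values shown sits). Going by the values given here, compound 1 and compound 2 differ from each other in more than one place, so no single step between them is counted.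

Compound 3 `COc1c(N2CC[C@@H](CN)C2)c(F)cc2c(=O)c(C(=O)O)cn(Cc3ccc(-c4ccc(F)cc4)cc3)c12` differs from compound 2 by methoxy in place of hydrogen on an aromatic carbon. Among the compounds with values here, no measured step covers this change. Within the data shown here, because compound 1 gives > 200000 nM as the only other member carrying the methoxy, a step toward weaker inhibition beyond the scatter is expected, a 2.2-fold higher number from compound 2 to compound 3 (0.33 log units; beyond the scatter), though the second point of difference in compound 1 leaves this uncertain. Compound 3 is therefore estimated at 150000 nM in this assay, with a range from 50000 nM to 400000 nM, and a real chance that only a limit is reported.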

Compound 3, half-maximal inhibitory concentration: 60900 nM
The estimate for compound 3 lay 2.5-fold (0.39 log units) above the measured number; the range from low to high includes it.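

In this assay, methoxy in place of hydrogen on the aromatic carbon ortho to the 3-(aminomethyl)pyrrolidin-1-yl group gives a 1.1-fold lower number from compound 2 to compound 3 (0.06 log units; within the scatter), so this position takes the methoxy with no readable difference. With the methoxy held in place, 4-fluorophenyl in place of 1H-pyrazol-1-yl gives an at least 3.2-fold lower number from compound 1 to compound 3 (0.51 log units; beyond the scatter), which ties the weak reading of compound 1 to the 1H-pyrazol-1-yl group and not to the methoxy. Compound 1 sits at a limit of the assay and not at a number: the limit of > 200000 nM in this assay, at which 1 of the 3 values shown sits.

Open, as far as these compounds go, is whether an ethoxy, a hydroxyl or a chloro on the same aromatic carbon would read like the methoxy. Also open, from the compounds shown here alone, is whether a plain phenyl or an amine in place of the 4-fluorophenyl would shift the reading in this assay.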